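The source may report more compounds than this note shows. Statements on the series, on what has been measured and on what is new or still open speak of the compounds shown alone.

Measured in an assay on cells for inhibition of cytochrome P450 11B1, mitochondrial (Homo sapiens); a higher number here means a weaker inhibitor, a lower number a stronger inhibitor:
- compound 1 `CC(C)CC1n2cncc2CN(Cc2ccc(OC(F)(F)F)cc2)S1(=O)=O` gives 544 nM
- compound 2 `COC(C)(C)CC1n2cncc2CN([C@@H](C)c2ccc(Cl)cc2)S1(=O)=O` gives 20.6 nM
- compound 3 `CC(C)CC1n2cncc2CN(CC2CC2)S1(=O)=O` gives 122 nM

Compound 2 stands lowest of the three numbers in this assay; its gaps to compound 3 and to compound 1 both lie beyond the scatter, so it is the strongest inhibitor of the three here. Compound 4 `C[C@@H](c1ccc(Cl)cc1)N1Cc2cncn2C(C[C@@H](O)c2ccccc2)S1(=O)=O` is not yet measured. It keeps the rest of compound 2 and differs only in one place: hydroxy(phenyl)methyl in place of 1-methoxy-1-methylethyl on a saturated chain carbon bound to a saturated ring carbon. Among the compounds with values here, no measured pair follows this change, so its effect is unknown. The expectation for the step is a modest move toward weaker inhibition, possibly none beyond the scatter, estimated as a 1.9-fold higher number from compound 2 to compound 4 (0.29 log units; within the scatter). Compound 4 is therefore expected to give about 40 nM in this assay, within 10 nM to 160 nM.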

Compound 4, half-maximal inhibitory concentration: 234 nM
Beside the measured number, compound 4's estimate is 5.9-fold (0.77 log units) below it, and the stated range ends below it.
By their numbers in this assay, from the lowest: compound 2; then compounds 3 and 4 (each within the scatter of the next); then compound 1.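

In this assay, hydroxy(phenyl)methyl in place of 1-methoxy-1-methylethyl on a saturated chain carbon bound to a saturated ring carbon gives an 11-fold higher number from compound 2 to compound 4 (1.06 log units; beyond the scatter), so the number in this assay depends on the group held at this position. Within the data shown here, this is the first step that changes one place only, as the earlier compounds offered no such comparison. Nothing measured here offers an explanation for this step.

As far as these compounds go, it remains open whether the phenyl ring, the hydroxy group or the absence of the methoxy group accounts for the step, which a plain hydroxyethyl chain or an amine at this position could help separate. From the compounds shown here alone, the opposite configuration at the hydroxy-bearing carbon of compound 4 also remains open.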